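This account rests on a few compounds, and the source may have more. Where it says the series, first, only, none or still open, it means among the compounds named here.

Measured compounds:
compound 1 `Cc1c(OCCCCOc2cccc(C(=O)O)c2)ccc(C(=O)CC2CCCC2)c1O` with 80.6%
compound 2 `COc1ccc(C(=O)O)cc1OCCCCOc1ccc(C(=O)CC2CCCC2)c(O)c1C` with 91.8%
compound 3 `Cc1cc(C(=O)O)ccc1OCCCCOc1ccc(C(=O)C(C)C)c(O)c1C` with 76.9%

All three numbers come from an assay on HEK293 cells for positive allosteric modulation of metabotropic glutamate receptor 2 (Rattus norvegicus), read by thallium flux, with a stated time of 2.5 min; on this read-out higher numbers stand for larger maximal responses and lower numbers for smaller maximal responses. Compound 3 sits within the scatter of compound 1, while compound 2 lies beyond the scatter above it. Among the measured compounds shown here, the one single-point step among the measured pairs is a number 11.2 percentage points higher from compound 1 to compound 2 (beyond the scatter), which concerns a methoxy group on the ring carrying the carboxylic acid and not the ketone side of the molecule.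

Compound 4 `Cc1cc(C(=O)O)ccc1OCCCCOc1ccc(C(=O)CC2CCCC2)c(O)c1C` is not yet measured. It differs from compound 3 as cyclopentylmethyl in place of isopropyl on a carbonyl carbon. For the measured compounds named here, no measured step changes this group, so nothing directly tells how much it matters. What can be said is that compound 1 already carries the cyclopentylmethyl ketone, and its value in this assay stands within the scatter of compound 3, which carries the isopropyl ketone; the two also differ elsewhere, so this is only a loose guide. The step is therefore expected to stay within the scatter, estimated as a number 3.1 percentage points higher from compound 3 to compound 4 (within the scatter). Compound 4 is expected to give about 80%, in a range from 68% to 92%.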

Compound 4, largest response reached (reported as percent of maximum), in percent of the reference or control that the assay uses: 84.6%
Estimate against measurement, compound 4: 4.6 percentage points below; the range from low to high includes it.
By their numbers in this assay, from the lowest: compounds 3, 1, 4 and 2 (each within the scatter of the next, the first and the last beyond it).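

In this assay, among the compounds shown here, the step on the carbonyl carbon gives the first direct reading of this group: cyclopentylmethyl in place of isopropyl gives a number 7.7 percentage points higher from compound 3 to compound 4 (within the scatter), so the two groups cannot be told apart here, although cyclopentylmethyl has a ring and more heavy atoms. With the cyclopentylmethyl ketone held constant, 4-carboxy-2-methylphenyl in place of 5-carboxy-2-methoxyphenyl gives a number 7.2 percentage points lower from compound 2 to compound 4 (within the scatter), and the same group in place of 3-carboxyphenyl gives a number 4 percentage points higher from compound 1 to compound 4 (within the scatter), so these changes on the acid-bearing ring also leave the response within the scatter. Nothing shown explains why these numbers fall as they do.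

Still open, as far as these compounds go, is whether a phenyl ring or a straight butyl chain on the carbonyl carbon would keep this response. The compounds shown also leave open what a tetrazole in place of the carboxylic acid, or a longer linking chain, would do.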